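The source may report more compounds than this note shows. Statements on the series, on what has been measured and on what is new or still open speak of the compounds shown alone.

Two analogues of the shared core have been measured. Compound 1 `COc1cc(Cl)cc(-c2nn(-c3cccc(NC(=O)Nc4ccc(Cl)c(C(F)(F)F)c4)c3)cc2-c2ccncc2)c1` gives 18.7% in a functional assay on NCI-H322M cells (Homo sapiens) for inhibition, read by sulforhodamine B assay, with a stated time of 48 h, tested at 10 uM; a higher number here means a weaker effect of the compound at the concentration tested, a lower number a stronger effect. Compound 2 `COc1cc(Cl)cc(-c2nn(-c3cccc(NC(=O)c4cc(C(F)(F)F)cc(C(F)(F)F)c4)c3)cc2-c2ccncc2)c1` gives 80.3% in this assay, the higher of the two numbers, with compound 1 lying lower by a margin beyond the scatter. Compound 3 `COc1cc(Cl)cc(-c2nn(-c3cccc(NC(=O)c4cccc(C(F)(F)F)c4)c3)cc2-c2ccncc2)c1` has not been measured; it differs from compound 2 as follows: hydrogen in place of trifluoromethyl on an aromatic carbon. Within the data shown here, no measured pair shows this change, so any step from compound 2 to compound 3 in this assay remains uncertain; a modest shift toward a lower number, or none beyond the scatter, is expected. Compound 3 is estimated at 70%, between 40% and 100%, implying a step of a number 10.3 percentage points lower from compound 2 to compound 3 (beyond the scatter).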

Compound 3, a percentage reported as activity, at one concentration (the size of the read-out at that concentration, not a potency): 78.6%
Compound 3: the middle estimate sits 8.6 percentage points below what was measured; measured number inside the range.
By their numbers in this assay, from the lowest: compound 1; then compounds 3 and 2 (each within the scatter of the next).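

In this assay, hydrogen in place of trifluoromethyl on this aromatic carbon gives a number 1.7 percentage points lower from compound 2 to compound 3 (within the scatter), so this pair shows no dependence on that group at this position. Among these compounds, the contrast lies at the carbonyl carbon: 3-(trifluoromethyl)phenyl in place of (4-chloro-3-(trifluoromethyl)phenyl)amino gives a number 59.9 percentage points higher from compound 1 to compound 3 (beyond the scatter), isolating a change in one place for the first time. No measured data explain either step. On these data alone, whether an amine or a nitrile on this aromatic carbon would read differently stays open. Also open, as far as these compounds go, is whether the amino link or the chloro substituent accounts for the contrast at the carbonyl carbon.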